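A Halogen Swap on a Weak Cytotoxic Scaffold

This account rests on a few compounds, and the source may have more. Where it says the series, first, only, none or still open, it means among the compounds named here.

For the measured compounds named here, compound 1 `C=CCn1c(=O)/c(=C\c2cccc(Br)c2)[nH]c(=O)/c1=C\c1ccccc1OC` is the only member of this small set with a numerical result. In a functional assay on HL-60 cells (Homo sapiens) for cytotoxicity, read by CCK-8 assay, with a stated time of 72 h (a higher number here means a weaker inhibitor, a lower number a stronger inhibitor), compound 1 gives 5200 nM, which makes it a weak inhibitor. Two relatives of the shared core fared worse: compound 2 `C=CCn1c(=O)/c(=C\c2cccc(Br)c2)[nH]c(=O)/c1=C\c1cccc(Br)c1` is reported in this assay as "not active" (no number reported), and compound 3 `COc1ccccc1/C=c1/[nH]c(=O)/c(=C\c2cccc(Cl)c2Cl)[nH]c1=O` is likewise reported in this assay as "not active" (no number reported).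

Compound 4 `C=CCn1c(=O)/c(=C\c2ccccc2Cl)[nH]c(=O)/c1=C\c1ccccc1OC` is the next compound to be tested. It differs from compound 1 in one place: 2-chlorophenyl in place of 3-bromophenyl on a double-bonded chain carbon bound to an aromatic carbon. Going by the values given here, no measured pair in this set shows what such a change does, so the direction of the step cannot be read from the data.

Given that the only numbered compound is weak and its two neighbours show no activity, compound 4 is expected to land in the same weak region, with the step of a 1.2-fold higher number from compound 1 to compound 4 (0.06 log units; within the scatter) expected to stay within the scatter. The estimate for compound 4 in this assay is 6000 nM, within a range from 2000 nM to 20000 nM.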

Compound 4, half-maximal inhibitory concentration: 4200 nM
Beside the measured number, compound 4's estimate is 1.4-fold (0.15 log units) above it; low and high end bracket the measured number.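

The step from 3-bromophenyl to 2-chlorophenyl on a double-bonded chain carbon bound to an aromatic carbon gives a 1.2-fold lower number from compound 1 to compound 4 (0.09 log units; within the scatter) in this assay. For the compounds shown here, this is the first pair in the set with a number on both sides, and it shows that this position can take a different halogen-bearing phenyl group while measurable activity remains. No supporting evidence is available to explain this outcome.

This change alters both the halogen and its location on the phenyl ring, so the contribution of each remains unresolved. The compounds shown also leave open how activity would respond at this position to a phenyl ring carrying an amine or a carboxylic acid in place of the halogen.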